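The source may hold more compounds than are shown below. What is called first, only, known or untested is meant among the compounds shown, and "the series" means these compounds.

In a functional assay on CNS cells (Homo sapiens) for antiproliferative activity (a lower number here means a stronger inhibitor of growth, a higher number a weaker inhibitor of growth), compound 1 (`Cc1cn2c(/C=N/NC(=N)N)c(-c3cccnc3)nc2s1`) gives 28200 nM and compound 2 (`N=C(N)N/N=C/c1c(-c2ccccn2)nc2sc(Cl)cn12`) gives 11500 nM. Compound 2 thus holds the lower of the two numbers, with a gap beyond the scatter, but the pair differs in more than one place. Compound 3 (`N=C(N)N/N=C/c1c(-c2cccnc2)nc2sc(Cl)cn12`) has pyridin-3-yl in place of pyridin-2-yl on an aromatic carbon. Compound 1 also carries pyridin-3-yl and gives 28200 nM, the only hint available, and it points to a slightly higher number. The expected change is small and not beyond the scatter, a 1.3-fold higher number from compound 2 to compound 3 (0.12 log units; within the scatter). For compound 3 the estimated value is 15000 nM, within a range of 7000 nM to 32000 nM.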

Compound 3, concentration for total growth inhibition: 31600 nM
Compound 3: the middle estimate sits 2.1-fold (0.32 log units) below what was measured; the measured number falls inside the stated range.
By their numbers in this assay, from the lowest: compound 2; then compounds 1 and 3 (each within the scatter of the next).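

In this assay, pyridin-3-yl in place of pyridin-2-yl on this aromatic carbon is a modest step beyond the scatter (a 2.7-fold higher number from compound 2 to compound 3 (0.44 log units; beyond the scatter)), so the two groups are not interchangeable here in the chloro series. With pyridin-3-yl held, chloro in place of methyl stays within the scatter (a 1.1-fold higher number from compound 1 to compound 3 (0.05 log units; within the scatter)). No measured evidence accounts for either result.

Open: whether methyl in place of chloro would also stay within the scatter alongside pyridin-2-yl, and whether pyridin-4-yl or phenyl on this carbon would read closer to compound 2 or compound 3.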